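The source may report more compounds than this note shows. Statements on the series, on what has been measured and on what is new or still open speak of the compounds shown alone.

Notes on the series, read in a physicochemical assay for metabolic stability, read by spectrophotometry, in phosphate buffer, at 25 degrees C, at pH 7.3; on this read-out higher numbers stand for a longer-lived compound and lower numbers for a shorter-lived compound. Compound 1 (`Cc1cccc(C(=O)n2cc(C#N)c3cccnc32)c1`) gives 1.9 h, compound 2 (`CCOC(=O)c1cn(C(=O)c2cccc(C)c2)c2ncccc12`) gives 3.5 h, and compound 3 (`CCOC(=O)c1cn(C(=O)C2CC2)c2ncccc12`) gives 14.4 h. Compound 2 therefore cannot be separated from compound 1, while compound 3 stands clearly higher than both.

For the measured compounds named here, compound 4 (`Cc1cccc(C(=O)n2cc(C(=O)Nc3ccccc3)c3cccnc32)c1`) has no measurement yet. Its structural change from compound 2 is anilino in place of ethoxy on a carbonyl carbon, so that ethoxycarbonyl becomes phenylcarbamoyl.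

Two measured steps offer guidance, and neither makes this exact change. The step that alters the same ethoxycarbonyl group is a 1.8-fold higher number from compound 1 to compound 2 (0.27 log units; within the scatter), which stays within the scatter and is the closer guide. The larger step, a 4.1-fold higher number from compound 2 to compound 3 (0.61 log units; beyond the scatter), is beyond the scatter but modest. It replaces the 3-methylphenyl, which compound 4 keeps, so it bears only weakly on this change.

A small upward move is expected in this assay, with nothing beyond the scatter. The expected step is a 1.3-fold higher number from compound 2 to compound 4 (0.11 log units; within the scatter). Going by the values given here, with no measured anilino compound, the range stays wide. For compound 4 the estimated half-life is 4.5 h, with an expected range of 2 h to 10 h.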

Compound 4, half-life: 3.4 h
For compound 4 the middle estimate is 1.3-fold (0.12 log units) above the measured one; the measured number falls inside the stated range.
By their numbers in this assay, from the lowest: compounds 1, 4 and 2 (each within the scatter of the next); then compound 3.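

In this assay, anilino can take the place of ethoxy on this carbonyl carbon without a readable shift (a 1.0-fold lower number from compound 2 to compound 4 (0.01 log units; within the scatter)), even though the entering group adds a six-membered aromatic ring of carbon only and a hydrogen-bond donor. The wider exchange on the aromatic carbon, phenylcarbamoyl in place of cyano, also stays within the scatter (a 1.8-fold higher number from compound 1 to compound 4 (0.25 log units; within the scatter)), so nitrile, ethoxycarbonyl and phenylcarbamoyl cannot be separated from one another in compounds that keep the 3-methylphenyl. No measured evidence is available that explains this result.

As far as these compounds go, it remains open whether phenylcarbamoyl would also match ethoxycarbonyl with cyclopropyl in place of the 3-methylphenyl, the setting of compound 3, where the ethoxycarbonyl compound has the clearly higher reading. Also open, from the compounds shown here alone, is whether a carboxylic acid, a primary amide or a morpholine amide at this aromatic carbon would move the half-life beyond the scatter, since the three groups compared here do not define how far this position can be changed.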